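The source may hold more compounds than are shown below. What is called first, only, known or untested is meant among the compounds shown, and "the series" means these compounds.

Measured so far in a functional assay on A549 cells (Homo sapiens) for inhibition, read by MTT assay, with a stated time of 72 h; on this read-out higher numbers stand for weaker inhibition and lower numbers for stronger inhibition:
- compound 1 `O=C(CCCCCCCN(Cc1ccc(F)cc1)c1ncc(C(=O)NCCCn2ccnc2)s1)NO`: 6600 nM
- compound 2 `O=C(NO)c1ccc(CN(Cc2ccc(F)cc2)c2ncc(C(=O)NCCCn3ccnc3)s2)cc1`: 7300 nM

Among the compounds with values here, compound 2 has only one measured neighbour, and the two values lie within the scatter of each other. The next compound is compound 3 `O=C(CCCCCCN(Cc1ccc(F)cc1)c1ncc(C(=O)NCCCn2ccnc2)s1)NO`, with this change: 5-(hydroxycarbamoyl)pentyl in place of 4-(hydroxycarbamoyl)phenyl on a saturated chain carbon bound to a nitrogen on an aromatic ring. In words, 5-(hydroxycarbamoyl)pentyl replaces 4-(hydroxycarbamoyl)phenyl on a saturated chain carbon bound to a nitrogen on an aromatic ring.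

Within the data shown here, one measured step bears on this, an exchange of the same kind in the opposite direction: a 1.1-fold higher number from compound 1 to compound 2 (0.04 log units; within the scatter). Among the measured compounds shown here, with only this step to go on, no shift beyond the scatter is expected in this assay. The expected step is small, a 1.1-fold lower number from compound 2 to compound 3 (0.05 log units; within the scatter), and its direction is not settled. The estimated value for compound 3 is 6500 nM, with an expected range of 3000 nM to 14000 nM.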

Compound 3, half-maximal inhibitory concentration: 9700 nM
For compound 3 the middle estimate is 1.5-fold (0.17 log units) below the measured one; low and high end bracket the measured number.
By their numbers in this assay, from the lowest: compounds 1, 2 and 3 (each within the scatter of the next).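

In this assay, 5-(hydroxycarbamoyl)pentyl in place of 4-(hydroxycarbamoyl)phenyl gives a 1.3-fold higher number from compound 2 to compound 3 (0.12 log units; within the scatter), so a second open chain, besides 6-(hydroxycarbamoyl)hexyl, stands level with the aromatic ring at this position. Within the chain, hydroxycarbamoyl in place of (hydroxycarbamoyl)methyl gives a 1.5-fold higher number from compound 1 to compound 3 (0.17 log units; within the scatter), so this change of chain length also shows no shift beyond the scatter, and the three compounds do not separate on this read-out. No measurement at hand offers an explanation for these values.

Still open, as far as these compounds go, is whether a chain much shorter than 5-(hydroxycarbamoyl)pentyl, or one longer than 6-(hydroxycarbamoyl)hexyl, would move the number beyond the scatter. Equally open, from the compounds shown here alone, is what a carboxylic acid or a primary amide in place of the hydroxycarbamoyl end would do on the shared core.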